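From an ester to an alcohol on the ring

The source may hold more compounds than are shown below. What is called first, only, known or untested is meant among the compounds shown, and "the series" means these compounds.

In a functional assay on RAW264.7 cells (Mus musculus), read by fluorescence (on this read-out lower numbers stand for stronger inhibition and higher numbers for weaker inhibition), compound 2 `CC(C)OC(=O)C1=CCCCC1S(=O)(=O)Cc1ccc(F)cc1Cl` gives 100 nM, the higher of the two numbers recorded. Going by the values given here, compound 1 `CCCOC(=O)C1=CCCCC1S(=O)(=O)Cc1ccc(F)cc1Cl` gives 14 nM; the change a 7.1-fold higher number from compound 1 to compound 2 (0.85 log units; beyond the scatter) is the only measured step available. Compound 3 `O=S(=O)(Cc1ccc(F)cc1Cl)C1CCCC=C1CO` is not yet measured. It differs from compound 2 by hydroxymethyl in place of isopropoxycarbonyl on a double-bonded ring carbon. Among the compounds with values here, no measured step covers this change directly: the one known step only swaps the alkyl part of the ester and nothing else. Because a 7.1-fold higher number from compound 1 to compound 2 (0.85 log units; beyond the scatter) was already beyond the scatter for that small change at this end of the core, a larger change there is expected to move the number further, most likely upward, though the direction remains uncertain. Compound 3 is therefore expected to give 600 nM in this assay, with a range from 100 nM to 4000 nM. This estimate means an expected step of a 6.0-fold higher number from compound 2 to compound 3 (0.78 log units; beyond the scatter).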

Compound 3, half-maximal inhibitory concentration: > 10000 nM
Compound 3: no number, only a limit; the forecaster's own chance of this, stated with the estimate: 10%; at least 16-fold (1.22 log units) between middle value and limit.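

In this assay compound 3 carries a limit and not a number: the limit of > 10000 nM in this assay, at which 1 of the 3 values shown sits.

Replacing the whole ester with hydroxymethyl on the double-bonded ring carbon gives an at least 100-fold higher number from compound 2 to compound 3 (2.00 log units; beyond the scatter), and from the propyl ester it gives an at least 710-fold higher number from compound 1 to compound 3 (2.85 log units; beyond the scatter). The earlier swap within the alkyl part of the ester gave a smaller step, a 7.1-fold higher number from compound 1 to compound 2 (0.85 log units; beyond the scatter), so this position responds far more strongly to losing the ester as a whole than to changing its alkyl part.

The compounds shown leave open which part of the change counts, as the carbonyl and the alkyl part go together and the hydroxyl enters in the same step. A carboxylic acid, an amide or a methyl ether on this ring carbon would separate these parts.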